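The compounds below may be only part of what the source reports. "The series", "measured", "known", "first", "only" and "open" are said of these compounds alone.

Two compounds in the series have numbers in an assay on ileum with muscarinic acetylcholine receptor M3 (Cavia porcellus) as the target; a higher number here means a weaker inhibitor, a lower number a stronger inhibitor. Compound 1 `CC(C)(C)NCCC(c1ccccc1)c1ccccc1` gives 792 nM. Compound 2 `CCc1nccn1CCC(C(N)=O)(c1ccccc1)c1ccccc1` gives 78.1 nM, the lowest of the two numbers, and its gap to compound 1 lies beyond the scatter. Compound 3 `Cc1ncn(CCC(C(N)=O)(c2ccccc2)c2ccccc2)c1C` is not yet measured; it differs from compound 2 by 4,5-dimethyl-1H-imidazol-1-yl in place of 2-ethyl-1H-imidazol-1-yl on a saturated chain carbon, three bonds along the chain from two aromatic carbons and a carbonyl carbon. The atoms stay the same and only their arrangement on the imidazole changes, so no step beyond the scatter is expected from compound 2 to compound 3, the estimated change being a 1.3-fold higher number from compound 2 to compound 3 (0.11 log units; within the scatter). Compound 3 is therefore expected to give about 100 nM, within a range from 35 nM to 300 nM.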

Compound 3, antagonist equilibrium constant: 2.7 nM
For compound 3 the middle estimate is 37-fold (1.57 log units) above the measured one, outside the stated range (below it).
By their numbers in this assay, from the lowest: compound 3; then compound 2; then compound 1.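

In this assay, the heavy atoms on the saturated chain carbon stay the same and only their arrangement on the imidazole changes, yet the result is a 29-fold lower number from compound 2 to compound 3 (1.46 log units; beyond the scatter). Potency at this position therefore depends strongly on the substitution pattern of the imidazole, not just on its atom content. No available data explain the step.

From the compounds shown here alone, whether the step comes from the 4,5-dimethyl pattern or from removing the 2-ethyl group remains open. An unsubstituted 1H-imidazol-1-yl group would help separate these, and a dimethylamino group would test whether the imidazole is needed.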